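Removing (1-bromoethenyl)carbonyl from compound 3

The compounds below may be only part of what the source reports. "The series", "measured", "known", "first", "only" and "open" are said of these compounds alone.

In a functional assay on SEM cells (Homo sapiens) for inhibition, read by MTT assay, with a stated time of 72 h (a higher number here means a weaker inhibitor, a lower number a stronger inhibitor), compound 3 `C=C(Br)C(=O)Nc1cccc(/C=C/C(=O)Nc2cc(OC)c(OC)c(OC)c2)c1` stands lowest of the three measured compounds at 18 nM and carries ((1-bromoethenyl)carbonyl)amino on the shared core. Compound 1 `COc1cccc(/C=C/C(=O)Nc2cc(OC)c(OC)c(OC)c2)c1` gives 18200 nM and compound 2 `COc1cc(NC(=O)/C=C/c2cccc(OCc3ccccc3)c2)cc(OC)c1OC` gives 8500 nM without that group. Compound 4 `COc1cc(NC(=O)/C=C/c2cccc(N)c2)cc(OC)c1OC` has hydrogen in place of (1-bromoethenyl)carbonyl on a nitrogen on an aromatic ring. Two large measured steps bear on this change, a 1000-fold lower number from compound 1 to compound 3 (3.00 log units; beyond the scatter) with methoxy replaced and a 470-fold lower number from compound 2 to compound 3 (2.67 log units; beyond the scatter) with benzyloxy replaced. Among the measured compounds shown here, no measured compound carries the plain amino group, so the comparison is indirect. A large step toward a higher number is therefore expected in this assay and is estimated as a 670-fold higher number from compound 3 to compound 4 (2.82 log units; beyond the scatter) overall. Compound 4 is estimated at 12000 nM (range 3000 nM to 40000 nM).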

Compound 4, half-maximal inhibitory concentration: 2810 nM
Compound 4: middle estimate off by 4.3-fold (0.63 log units), on the high side; the whole stated range lies above it.
By their numbers in this assay, from the lowest: compound 3; then compound 4; then compound 2; then compound 1.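

In this assay the plain amino group on this aromatic carbon gives a lower number than either ether, in two modest steps: a 3.0-fold lower number from compound 2 to compound 4 (0.48 log units; beyond the scatter) and a 6.5-fold lower number from compound 1 to compound 4 (0.81 log units; beyond the scatter). Most of the advantage of compound 3 therefore goes with the (1-bromoethenyl)carbonyl on the nitrogen itself, and its loss is a large step, a 160-fold higher number from compound 3 to compound 4 (2.19 log units; beyond the scatter). The compounds shown leave open whether an acryloyl or a chloroacetyl group on the same nitrogen would keep the low number of compound 3. Nothing given here accounts for the size of these steps.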